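The compounds below may be only part of what the source reports. "The series", "measured", "known", "first", "only" and "open" are said of these compounds alone.

Compound 1, `CCN(Cc1ccccc1OC)C(=O)c1c(-c2ccccc2C)c2ccccc2c(=O)n1C`: 34 nM
Compound 2, `Cc1cc2c(-c3ccccc3)c(NC(=O)N(C)Cc3ccccc3Cl)n(C)c(=O)c2cc1C`: 4.2 nM
Compound 3, `Cc1cc(C)cc(CN(C)C(=O)Nc2c(-c3ccccc3)c3cc(C)c(C)cc3c(=O)n2C)c1`: 28 nM

In an assay on IM-9 cells for binding affinity to Substance-P receptor (Homo sapiens) (a higher number here means a weaker inhibitor, a lower number a stronger inhibitor), compound 3 gives 28 nM, the second highest of the three numbers. Compound 1 gives 34 nM, which lies within the scatter of compound 3. Compound 2 gives 4.2 nM, clearly the lowest and so the strongest inhibitor of the three.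

Compound 4, `CCN(Cc1ccccc1)C(=O)Nc1c(-c2ccccc2)c2cc(C)c(C)cc2c(=O)n1C`, differs from compound 3 in one place: benzyl(ethyl)amino in place of (3,5-dimethylbenzyl)(methyl)amino on a carbonyl carbon. Among the measured compounds shown here, only one measured step touches the same part of the molecule, the step of a 6.7-fold higher number from compound 2 to compound 3 (0.82 log units; beyond the scatter), where a 3,5-dimethylphenyl group replaced a 2-chlorophenyl group on the chain carbon next to the nitrogen and the number rose by a modest amount. Compound 4 carries a plain benzyl at that position, with neither the two methyl groups of compound 3 nor the chlorine of compound 2, and an ethyl instead of a methyl on the nitrogen. For the measured compounds named here, no measured step isolates the methyl-to-ethyl change; compound 1 has an ethyl there but differs in several other places, so its value can only be noted alongside.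

Compound 4 is therefore expected to fall somewhat, by about a 2.3-fold lower number from compound 3 to compound 4 (0.37 log units; beyond the scatter), landing between compound 3 and compound 2. The estimate for compound 4 is 12 nM, with a range of 4 nM to 35 nM.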

Compound 4, half-maximal inhibitory concentration: 66 nM
Compound 4: middle estimate off by 5.5-fold (0.74 log units), on the low side; the whole stated range lies below it.
By their numbers in this assay, from the lowest: compound 2; then compounds 3, 1 and 4 (each within the scatter of the next, the first and the last beyond it).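

In this assay, the plain benzyl with ethyl does not move the number towards that of the chlorine-bearing compound, as losing the two methyl groups of compound 3 might have suggested: the change gives a 2.4-fold higher number from compound 3 to compound 4 (0.37 log units; beyond the scatter). The other comparison, a 16-fold higher number from compound 2 to compound 4 (1.20 log units; beyond the scatter), shows that changing only the amino group on the carbonyl carbon, with the rest of the molecule the same, can shift the number a long way, so this position matters strongly for this assay. No measurement on hand explains why these groups rank as they do.

Each of these two steps changes the ring substitution and the chain on the nitrogen together, so the compounds shown leave open how much of either step belongs to the ethyl and how much to the ring. A benzyl(methyl)amino group would separate the two, and a 2-chlorobenzyl group paired with ethyl on the nitrogen would show whether the chlorine keeps its low number when the methyl is replaced.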